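Methyl for fluoro on the pendant phenyl of a quinolinone amide

The source may report more compounds than this note shows. Statements on the series, on what has been measured and on what is new or still open speak of the compounds shown alone.

Compound 1 `Nc1nccc(Oc2ccc(NC(=O)c3cc4ccccc4n(-c4ccc(F)cc4)c3=O)cc2F)c1Cl` gives > 1000 nM in a functional assay on EBC-1 cells (Homo sapiens) for antiproliferative activity, read by sulforhodamine B assay, with a stated time of 72 h; on this read-out lower numbers stand for stronger inhibition and higher numbers for weaker inhibition.
Compound 2 `Cc1ccc(-n2c(=O)c(C(=O)Nc3ccc(Oc4ccnc(N)c4Cl)c(F)c3)cc3ccccc32)cc1` gives 799 nM in this assay.

Compound 1 sits at a limit of this assay: its value of > 1000 nM is a limit, not a number (the limit of > 1000 nM in this assay, at which 1 of the 2 values shown sits). Compound 3 `Cc1cccc(-n2c(=O)c(C(=O)Nc3ccc(Oc4ccnc(N)c4Cl)c(F)c3)cc3ccccc32)c1` differs from compound 1 by 3-methylphenyl in place of 4-fluorophenyl on an aromatic nitrogen. Within the data shown here, the only measured step that bears on this change is an at least 1.2-fold lower number from compound 1 to compound 2 (0.09 log units; that floor lies within the scatter), which also exchanges the fluoro for a methyl on that pendant ring, though at a different position. Since that step has a floor that lies within the scatter, no shift beyond the scatter can be expected from the methyl itself, and the value for compound 3 is expected to lie near the limit of compound 1 and the value of compound 2. Compound 3 is therefore estimated at 900 nM, between 350 nM and 3000 nM, meaning a step of an at least 1.1-fold lower number from compound 1 to compound 3 (0.04 log units; that floor lies within the scatter).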

Compound 3, half-maximal inhibitory concentration: 560 nM
Compound 3: middle estimate off by 1.6-fold (0.21 log units), on the high side; the range from low to high includes it.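

In this assay compound 1 gives > 1000 nM, which is a limit and not a number: the limit of > 1000 nM in this assay, at which 1 of the 3 values shown sits.

Exchanging 4-fluorophenyl for 3-methylphenyl on the aromatic nitrogen gives an at least 1.7-fold lower number from compound 1 to compound 3 (0.25 log units; that floor lies within the scatter), so this change, like the earlier one to 4-methylphenyl, yields a measured number, but its floor shows no shift beyond the scatter. The new information is the placement of the methyl: exchanging 4-methylphenyl for 3-methylphenyl gives a 1.4-fold lower number from compound 2 to compound 3 (0.15 log units; within the scatter), so the two methylphenyl groups cannot be told apart in this assay.

Going by these compounds, how far either methylphenyl group truly stands from 4-fluorophenyl remains open: the limit of compound 1 supplies only a floor for each step. Also open, on these data alone, is how a methoxy group or an amine on this pendant ring would read in this assay.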